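Hydroxy in Place of Hydrogen on a Weakly Active Core

The compounds below may be only part of what the source reports. "The series", "measured", "known", "first", "only" and "open" are said of these compounds alone.

Compound 1, `COc1ccc(C(=O)/C=C/c2ccc(N(c3ccccc3)c3ccccc3)cc2)c2c1C=CC(C)(C)O2`: > 10000 nM
Compound 2, `COc1ccc(C(=O)/C=C/c2ccccc2)c2c1C=CC(C)(C)O2`: > 10000 nM
Compound 3, `COc1ccc(C(=O)/C=C/c2cccc(C(F)(F)F)c2)c2c1C=CC(C)(C)O2`: 7870 nM

All three were tested in a functional assay on SW-620 cells (Homo sapiens) for antiproliferative activity, read by MTT assay, with a stated time of 24 h; a lower number here means a stronger inhibitor, a higher number a weaker inhibitor. For compound 1 the value is a limit of the assay, not a number. For compound 2 the value is likewise only a limit. Among the compounds with values here, compound 3 is the one compound with a number, 7870 nM. Compound 2 therefore stands at the limit of this assay, the same limit at which compound 1 sits (the limit of > 10000 nM in this assay, at which 2 of the 3 values shown sit), and only compound 3 lies below it.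

Compound 4, `COc1ccc(C(=O)/C=C/c2ccc(O)cc2)c2c1C=CC(C)(C)O2`, differs from compound 2 by hydroxy in place of hydrogen on an aromatic carbon. Within the data shown here, the only measured step that bears on this change is an at least 1.2-fold lower number from compound 2 to compound 3 (0.10 log units; that floor lies within the scatter), a different group entering the same kind of place, and its floor lies within the scatter. On that basis compound 4 is expected to remain close to compound 2, so the step of an at least 1.1-fold lower number from compound 2 to compound 4 (0.04 log units; that floor lies within the scatter) is expected to stay within the scatter, with a fair chance that only a limit is again reported. The estimate for compound 4 is 9000 nM, with a range from 3000 nM to 25000 nM.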

Compound 4, half-maximal inhibitory concentration: > 10000 nM
Compound 4 was reported as a limit; the forecaster's own chance of this, stated with the estimate: 55%; middle value at least 1.1-fold (0.04 log units) from the limit.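

In this assay compound 4 gives > 10000 nM, a limit of the assay and not a number. Compound 2 sits at the same limit, so the step between compound 2 and compound 4 cannot be read: the limit of > 10000 nM in this assay, at which 3 of the 4 values shown sit.

From the compounds shown here alone, whether hydroxy in place of hydrogen on an aromatic carbon changes the activity at all stays open.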